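A few compounds are considered here, and "the series" means these few. Any claim that something is new, unique, unknown or untested is made for them only; others in the source may bear on it.

Compound 1 `CCOC(=O)C1=C(Nc2ccccc2)S/C(=C\c2ccccc2)C1=O` heads a small set in which the aryl group on the exocyclic double bond is varied while the rest of the core is kept. In a functional assay on MCF7 cells (Homo sapiens) for inhibition, read by MTT assay, with a stated time of 72 h, tested at 10 uM (a higher number here means more inhibition at the concentration tested (going by the name of the read-out), a lower number less inhibition), compound 1 gives 23.6%, the highest of the two numbers reported; the nearest is compound 3 `CCOC(=O)C1=C(Nc2ccccc2)S/C(=C\c2cc(OC)c(O)c(OC)c2)C1=O`, which gives 12.9%, a value that stands lower than that of compound 1 by more than the scatter. Compound 2 `CCOC(=O)C1=C(Nc2ccccc2)S/C(=C\c2ccccc2C(F)(F)F)C1=O` sits at a limit of this assay, reported only as < 10% and not as a number; the limit of < 10% in this assay, at which 1 of the 3 values shown sits, marks that limit.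

Compound 4 `CCOC(=O)C1=C(Nc2ccccc2)S/C(=C\c2cc3cccnc3[nH]2)C1=O` carries the change (a group of 9 heavy atoms (7 carbon, 2 nitrogen; one five-membered aromatic ring with 1 hetero atom, one six-membered aromatic ring with 1 hetero atom) in place of a group of 6 heavy atoms (6 carbon; one six-membered aromatic ring of carbon only), on a double-bonded chain carbon bound to a double-bonded ring carbon). Among the compounds with values here, only one measured step differs from compound 1 in a single place, the trifluoromethyl step a number at least 13.6 percentage points lower from compound 1 to compound 2 (beyond the scatter), and it runs downward. Compound 3, too, stands below compound 1 beyond the scatter. Nothing measured shows a replacement on the aryl group that raised the read-out in this assay, and the change in compound 4 is larger than either of those measured, so a downward step is the expectation. Compound 4 is therefore estimated to give about 13% in this assay, between 5% and 26%. That estimate corresponds to a step of a number 10.6 percentage points lower from compound 1 to compound 4 (beyond the scatter), with a fair chance that the assay reports only its limit.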

Compound 4, a percentage reported as inhibition, at one concentration (the size of the read-out at that concentration, not a potency): 18.2%
Estimate against measurement, compound 4: 5.2 percentage points below; low and high end bracket the measured number.
By their numbers in this assay, from the lowest: compounds 3, 4 and 1 (each within the scatter of the next, the first and the last beyond it). At a limit, below all of these: compound 2.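

Replacing the phenyl with the larger group of 9 heavy atoms, on a double-bonded chain carbon bound to a double-bonded ring carbon, gives in this assay a number 5.4 percentage points lower from compound 1 to compound 4 (within the scatter). Within the data shown here, this is the first single change at this position that stays within the scatter of compound 1, so a second aromatic ring, a ring nitrogen and a hydrogen-bond donor and acceptor can enter here without a clear shift in the read-out, whereas the trifluoromethyl change gave a number at least 13.6 percentage points lower from compound 1 to compound 2 (beyond the scatter). Compound 2 remains the only compound at a limit, which is not a number: the limit of < 10% in this assay, at which 1 of the 4 values shown sits.

What the compounds shown leave open is whether this position accepts anything other than an aromatic group, such as a morpholine ring or a straight alkyl chain, or a phenyl carrying a carboxylic acid or an amine. They also leave open how the read-out responds when the shared core itself changes, for example with an amide in place of the ethyl ester or a substituent on the anilino phenyl ring.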